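This account rests on a few compounds, and the source may have more. Where it says the series, first, only, none or still open, it means among the compounds named here.

Measured compounds:
- compound 1 `CC(C)OC(=O)C1=CN(C(=O)c2ccc(C#N)cc2)CC(C)(C)c2cc(C#N)[nH]c21`: 35 nM
- compound 2 `CC(C)OC(=O)C1=CN(C(=O)c2cccs2)CC(C)(C)c2cc(C#N)[nH]c21`: 16 nM

Both numbers come from an assay on HEK293 cells for agonist activity at Bile acid receptor (Homo sapiens), read by a luciferase reporter; a lower number here means that less compound is needed, a higher number that more compound is needed for the effect. Among the compounds with values here, compound 2 gives 16 nM and stands lowest of the two; its only neighbour is compound 1, which in this assay gives 35 nM. Within the data shown here, the single measured step, a 2.2-fold lower number from compound 1 to compound 2 (0.34 log units; beyond the scatter), is the whole basis for judging the next change.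

Compound 3 `CC(C)OC(=O)C1=CN(C(=O)c2ccc(F)cc2)CC(C)(C)c2cc(C#N)[nH]c21` is not yet measured. It differs from compound 2 by 4-fluorophenyl in place of thiophen-2-yl on a carbonyl carbon. The change returns from the five-membered ring to a six-membered carbon ring, so the step from compound 1 to compound 2 bears on it, read in reverse: leaving thiophen-2-yl for a substituted phenyl was worth a 2.2-fold lower number from compound 1 to compound 2 (0.34 log units; beyond the scatter) in the forward direction. Among the measured compounds shown here, the substituent on the phenyl is now fluorine rather than nitrile, for which no step is available, so the size is taken from the one step known and given a wide range. For compound 3 a modestly higher number is expected, a 1.9-fold higher number from compound 2 to compound 3 (0.27 log units; within the scatter), landing near the figure of compound 1. The estimate for compound 3 is 30 nM, with a range from 12 nM to 75 nM.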

Compound 3, half-maximal effective concentration: 5 nM
Compound 3: middle estimate off by 6.0-fold (0.78 log units), on the high side; measured number outside the range, below it.
By their numbers in this assay, from the lowest: compound 3; then compound 2; then compound 1.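

In this assay, the ring type on this carbonyl carbon does not settle the result: the two phenyl compounds fall on either side of the thiophene, with a 3.2-fold lower number from compound 2 to compound 3 (0.51 log units; beyond the scatter) running opposite in direction to a 2.2-fold lower number from compound 1 to compound 2 (0.34 log units; beyond the scatter). The substituent on the phenyl ring therefore matters at least as much as the choice of ring, and a 7.0-fold lower number from compound 1 to compound 3 (0.85 log units; beyond the scatter) is the widest step in the series, so 4-fluorophenyl and 4-cyanophenyl cannot be treated as interchangeable in these notes. No measurement in hand accounts for any of these steps.

The compounds shown leave open how an unsubstituted phenyl, a chloro or methoxy group, or an amine or carboxylic acid on that ring would compare with 4-fluorophenyl, and whether a fluorine on the thiophene would move the number in the same direction. As far as these compounds go, the ester and the nitrile of the shared core stay the same throughout, so it also remains open whether this order of the three acyl groups would hold with a carboxylic acid or an ethyl ester in place of the present ester.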